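A few compounds are considered here, and "the series" means these few. Any claim that something is new, unique, unknown or untested is made for them only; others in the source may bear on it.

Measured compounds:
compound 1, `COc1ccc(-c2cc3ccccc3nc2/C=C/C(=O)c2ccc(OC)cc2OC)cc1`: 7990 nM
compound 2, `COc1ccc(-c2cc3ccccc3nc2/C=C/C(=O)c2sccc2N)cc1`: > 10000 nM

In a functional assay on A549 cells (Homo sapiens) for antiproliferative activity, read by XTT assay, with a stated time of 72 h (a higher number here means a weaker inhibitor, a lower number a stronger inhibitor), compound 1 gives 7990 nM. For compound 2 the assay reports only a limit, > 10000 nM (the limit of > 10000 nM in this assay, at which 1 of the 2 values shown sits). Going by the values given here, the single measured step, an at least 1.2-fold higher number from compound 1 to compound 2 (0.09 log units; that floor lies within the scatter), is thus known only by its floor, and compound 2 stands at the weak end of the two values shown.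

Compound 3, `COc1ccc(-c2cc3ccccc3nc2/C=C/C(=O)c2c[nH]c3ccccc23)cc1`, differs from compound 2 by 1H-indol-3-yl in place of 3-aminothiophen-2-yl on a carbonyl carbon. Among the compounds with values here, no measured step covers this exchange directly; the one step that exists, an at least 1.2-fold higher number from compound 1 to compound 2 (0.09 log units; that floor lies within the scatter), shows that the group on the carbonyl carbon can shift the number in this assay, but gives no direction for an indolyl. Compound 3 is therefore expected to remain near the weak end, with the step of an at least 1.1-fold lower number from compound 2 to compound 3 (0.04 log units; that floor lies within the scatter) estimated as small. The estimate for compound 3 in this assay is 9000 nM, within 2500 nM to 30000 nM.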

Compound 3, half-maximal inhibitory concentration: > 10000 nM
Compound 3 ended at the assay's limit; the forecaster's own chance of this, stated with the estimate: 50%; middle value at least 1.1-fold (0.04 log units) away from the limit.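

With 1H-indol-3-yl on the carbonyl carbon, the larger of the two groups with a ring nitrogen, this assay again ends in a limit, so a second group at this place now sits there with 3-aminothiophen-2-yl: the limit of > 10000 nM in this assay, at which 2 of the 3 values shown sit. Replacing 2,4-dimethoxyphenyl with 1H-indol-3-yl gives an at least 1.2-fold higher number from compound 1 to compound 3 (0.09 log units; that floor lies within the scatter), so this exchange, like the earlier one, shows no change that can be told apart from the scatter. The step between compound 2 and compound 3 cannot be read, as both values are limits.

On these data alone, how far compound 2 and compound 3 lie past that limit remains open. Also open, as far as these compounds go, is whether any other group on this carbonyl carbon, such as an unsubstituted phenyl, a pyridinyl or a 1-methylindol-3-yl, would give a number clearly lower than that of compound 1.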